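From compound 3 to compound 4 in the series

The source may report more compounds than this note shows. Statements on the series, on what has been measured and on what is new or still open speak of the compounds shown alone.

In a functional assay on HCT-116 cells (Homo sapiens) for inhibition, read by CCK-8 assay, with a stated time of 48 h (a higher number here means a weaker inhibitor, a lower number a stronger inhibitor), three compounds on the shared core have been measured. Compound 1 `COc1cc(-c2ccnc3cc(-c4ccc(F)cc4)nn23)cc(OC)c1OC` stands at 5030 nM and compound 2 `COc1cc(-c2ccnc3cc(-c4ccc5cc[nH]c5c4)nn23)cc(OC)c1OC` stands at 187 nM on this read-out. Compound 3 `COc1cc(-c2ccnc3cc(-c4cn(C)c5ccccc45)nn23)cc(OC)c1OC` gives 762 nM and so holds the middle place, the second highest of the three numbers.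

Compound 4 `COc1cc(-c2ccnc3cc(-c4ccc5cnn(C)c5c4)nn23)cc(OC)c1OC` is not yet measured, and its change from compound 3 is a swap of groups on an aromatic carbon (1-methyl-1H-indazol-6-yl in place of 1-methyl-1H-indol-3-yl on an aromatic carbon). Among the compounds with values here, three measured steps bear on it. Leaving 4-fluorophenyl brought one large drop (a 27-fold lower number from compound 1 to compound 2 (1.43 log units; beyond the scatter)) and one modest drop (a 6.6-fold lower number from compound 1 to compound 3 (0.82 log units; beyond the scatter)), and the two indolyl groups sit a modest step apart (a 4.1-fold higher number from compound 2 to compound 3 (0.61 log units; beyond the scatter)).

Within the data shown here, the entering group shares the 6-yl attachment of compound 2 (187 nM), yet no measured compound carries 1-methyl-1H-indazol-6-yl. A modest fall is therefore expected (a 2.5-fold lower number from compound 3 to compound 4 (0.40 log units; beyond the scatter)). In this assay compound 4 is estimated at 300 nM within an expected range (70 nM to 1300 nM).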

Compound 4, half-maximal inhibitory concentration: 2440 nM
Compound 4: the middle estimate sits 8.1-fold (0.91 log units) below what was measured; measured number above the stated range.
By their numbers in this assay, from the lowest: compound 2; then compound 3; then compound 4; then compound 1.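

In this assay, the 6-yl attachment alone does not carry the standing of compound 2 at this position on the shared core, with a 13-fold higher number from compound 2 to compound 4 (1.12 log units; beyond the scatter). The result also reverses the order expected from attachment, as 1-methyl-1H-indazol-6-yl falls behind the 3-yl group, with a 3.2-fold higher number from compound 3 to compound 4 (0.51 log units; beyond the scatter), so attachment by itself does not rank these two-ring groups. Little of the gain over 4-fluorophenyl survives in this group, with a 2.1-fold lower number from compound 1 to compound 4 (0.31 log units; beyond the scatter), although all three two-ring groups still give lower numbers than 4-fluorophenyl.

The step from compound 2 to compound 4 changes the ring nitrogen count and the methyl group together, and nothing shown explains any of these steps. Going by these compounds, how 1H-indazol-6-yl or 1-methyl-1H-indol-6-yl would stand, which could separate those two changes, remains open.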